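The compounds below may be only part of what the source reports. "The series", "measured", "known", "first", "only" and "open" are said of these compounds alone.

Measured so far in a physicochemical assay for solubility, read by spectrophotometry, in phosphate buffer, with a stated time of 18 h, at pH 7.4; a higher number here means a more soluble compound, a lower number a less soluble compound:
- Compound 1 `CCc1ccc(-c2nc3c(c(C)nn3-c3ccccc3)c(-c3ccccc3C)c2C#N)cc1`: 6000 nM
- Compound 2 `CCc1ccc(-c2nc3c(c(C)nn3-c3ccccc3)c(-c3ccccc3C(=O)OC)c2C#N)cc1`: 17000 nM

Of these two compounds, compound 2 has the higher number, at 17000 nM. The next compound to consider is compound 3 `C#Cc1ccccc1-c1c(C#N)c(-c2ccc(CC)cc2)nc2c1c(C)nn2-c1ccccc1`, which has not yet been measured. It carries ethynyl in place of methoxycarbonyl on an aromatic carbon, and the exchange can be counted as ethynyl in place of methoxycarbonyl on an aromatic carbon. The group sits on a six-membered aromatic ring of carbon only, ortho to a large group.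

Within the data shown here, only one measured step bears on this change: a 2.8-fold higher number from compound 1 to compound 2 (0.45 log units; beyond the scatter). That modest step brought in methoxycarbonyl where compound 1 has methyl. Among the measured compounds shown here, compound 3 loses that methoxycarbonyl again, but ethynyl is not methyl, and no compound with ethynyl has been measured yet. The comparison is therefore only a rough guide. A modest fall of similar size in this assay is expected, and the estimated change is a 2.4-fold lower number from compound 2 to compound 3 (0.39 log units; beyond the scatter). For compound 3, the estimated value is 7000 nM, with an expected range from 3000 nM to 16000 nM.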

Compound 3, solubility: 46000 nM
Beside the measured number, compound 3's estimate is 6.6-fold (0.82 log units) below it; the measured number lies above the stated range.
By their numbers in this assay, from the lowest: compound 1; then compound 2; then compound 3.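

In this assay, this place on the aromatic ring now has three groups to compare, and the order differs from what the first pair alone might have suggested. Ethynyl in place of methoxycarbonyl gives a 2.7-fold higher number from compound 2 to compound 3 (0.43 log units; beyond the scatter), so a group with hydrogen-bond acceptors is not required for a higher number here: ethynyl has none, while methoxycarbonyl has 2. Ethynyl in place of methyl gives a 7.7-fold higher number from compound 1 to compound 3 (0.88 log units; beyond the scatter), the widest gap among the three compounds, which shows that a small change at this one place can move the number by more than the usual scatter.

Nothing measured here accounts for why the three groups fall in this order. Three groups at a single place on the ring also leave open where an amine, a carboxylic acid or a longer chain such as propynyl would fall, and whether ethynyl would give a similar step on a different core.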